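From isobutyl to 4-bromophenyl on a carbonyl carbon

This account rests on a few compounds, and the source may have more. Where it says the series, first, only, none or still open, it means among the compounds named here.

Compound 1 `CC(C)CC(=O)CC1Oc2cc(O)ccc2C=C1c1ccc(O)cc1`: 67000 nM
Compound 2 `CCc1ccc(C(=O)CC2Oc3cc(O)ccc3C=C2c2ccc(O)cc2)cc1`: 198000 nM
Compound 3 `COc1ccc(C(=O)CC2Oc3cc(O)ccc3C=C2c2ccc(O)cc2)cc1`: 7600 nM

All three compounds were tested in a functional assay on MDA-MB-231 cells (Homo sapiens) for antiproliferative activity, read by spectrophotometry and resazurin assay, with a stated time of 72 h; a lower number here means a stronger inhibitor, a higher number a weaker inhibitor. Compound 1 stands in the middle of the three numbers, as the second highest. Compound 4 `O=C(CC1Oc2cc(O)ccc2C=C1c1ccc(O)cc1)c1ccc(Br)cc1` has not yet been measured. It carries 4-bromophenyl in place of isobutyl on a carbonyl carbon.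

Two measured steps make the same kind of change at that place, and they point in opposite directions. One is a 3.0-fold higher number from compound 1 to compound 2 (0.47 log units; beyond the scatter). The other is an 8.8-fold lower number from compound 1 to compound 3 (0.95 log units; beyond the scatter). The two aryl compounds also differ widely from each other, with methoxy in place of ethyl on an aromatic carbon giving a 26-fold lower number from compound 2 to compound 3 (1.42 log units; beyond the scatter). A single change on the aryl group can therefore move the number a long way, and nothing measured here shows where a bromine-bearing aryl group will fall. No firm direction follows, so the expectation in this assay is for no step beyond the scatter, held with wide uncertainty. The expected change is a 1.7-fold lower number from compound 1 to compound 4 (0.22 log units; within the scatter). For compound 4 the estimated value is 40000 nM, with an expected range from 8000 nM to 200000 nM.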

Compound 4, half-maximal inhibitory concentration: 37000 nM
For compound 4 the middle estimate is 1.1-fold (0.03 log units) above the measured one, and the stated range covers the measured number.
By their numbers in this assay, from the lowest: compound 3; then compounds 4 and 1 (each within the scatter of the next); then compound 2.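

In this assay, 4-bromophenyl in place of isobutyl on a carbonyl carbon gives a 1.8-fold lower number from compound 1 to compound 4 (0.26 log units; within the scatter) and so stays within the scatter, which shows that an aryl group at this place need not move the number away from that of the isobutyl compound. The group carried on the aryl ring makes the clearer difference: bromo in place of methoxy gives a 4.9-fold higher number from compound 3 to compound 4 (0.69 log units; beyond the scatter) and bromo in place of ethyl gives a 5.4-fold lower number from compound 2 to compound 4 (0.73 log units; beyond the scatter), so compound 4 lies apart from both of the other aryl compounds, on opposite sides. Nothing available here accounts for these differences.

The compounds shown leave open whether the low number of compound 3 belongs to methoxy alone or could also be reached with an amine or a carboxylic acid in that place on the aryl group. They also leave open whether a longer chain in place of isobutyl on the carbonyl carbon would change the number or stay within the scatter of compound 1.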